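The source may report more compounds than this note shows. Statements on the series, on what has been measured and on what is new or still open speak of the compounds shown alone.

In a functional assay on Capan-2 cells (Homo sapiens) for inhibition, read by MTT assay, with a stated time of 72 h (on this read-out higher numbers stand for weaker inhibition of growth and lower numbers for stronger inhibition of growth), the measured compounds stand as follows: compound 1 `CC(C)(C)c1ccc(CNCCCNS(=O)(=O)c2cc(C(F)(F)F)cc(C(F)(F)F)c2)cc1` at 2100 nM; compound 2 `O=S(=O)(NCCNCc1ccc(-c2ccccc2)cc1)c1cc(C(F)(F)F)cc(C(F)(F)F)c1` at 2400 nM; compound 3 `O=S(=O)(NCCCNCc1ccc(-c2ccccc2)cc1)c1cc(C(F)(F)F)cc(C(F)(F)F)c1` at 2200 nM.

Compound 4 `CC(C)(C)c1ccc(CNCCNS(=O)(=O)c2cc(C(F)(F)F)cc(C(F)(F)F)c2)cc1` has not yet been measured. It differs from compound 2 in one place, described as tert-butyl in place of phenyl on an aromatic carbon. Among the measured compounds shown here, the same change, at the same place, is already covered by a measured pair: compound 1 differs from compound 3 in the same way, (tert-butyl in place of phenyl on an aromatic carbon), and in this assay that pair shows a 1.0-fold lower number from compound 3 to compound 1 (0.02 log units; within the scatter), which is as close to no movement as a pair of measurements gets. Compounds 2 and 3 carry different cores, and the difference between the two cores is not broken down here; their values in this assay lie within the usual scatter of each other, so nothing separates them. For the measured compounds named here, since this change occurs only twice among the four compounds, the one measured instance is the sole basis available.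

On that basis, compound 4 is expected to show a 1.0-fold lower number from compound 2 to compound 4 (0.02 log units; within the scatter) in this assay, because the matching pair gave a 1.0-fold lower number from compound 3 to compound 1 (0.02 log units; within the scatter). Compound 4 is therefore estimated at 2300 nM, with a likely range from 1200 nM to 4500 nM.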

Compound 4, concentration for 50% growth inhibition: 13000 nM
For compound 4 the middle estimate is 5.7-fold (0.75 log units) below the measured one; measured number outside the range, above it.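

On the core of compound 2, tert-butyl in place of phenyl gives a 5.4-fold higher number from compound 2 to compound 4 (0.73 log units; beyond the scatter), so the near absence of movement in the earlier pair did not hold on this core. In this assay, the effect of this change therefore cannot be carried unaltered from one of these two cores to the other: the same change on two cores in this assay, a 1.0-fold lower number (0.02 log units; within the scatter) from compound 3 to compound 1 and a 5.4-fold higher number (0.73 log units; beyond the scatter) from compound 2 to compound 4, 5.7-fold (0.75 log units) apart, beyond the scatter of two such steps. This does not show why the two cores respond differently or how the change would behave on any further core, as the comparison rests on one pair for each core.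

The compounds shown leave open whether a longer chain in the core would respond to this change as the core of compound 1 does or as the core of compound 2 does. They also leave open whether a smaller group such as methyl, or a ring such as cyclohexyl, in place of phenyl would show the same dependence on the core.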